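Piperidinyl groups in place of trifluoromethyl: kinetic solubility

This account rests on a few compounds, and the source may have more. Where it says the series, first, only, none or still open, it means among the compounds named here.

Compound 1 `O=C(Nc1ccnnc1)c1cc(C(F)(F)F)ccc1OCc1ccccc1` carries a trifluoromethyl group on the shared core. In a physicochemical assay for solubility, measured as kinetic solubility (on this read-out lower numbers stand for lower solubility and higher numbers for higher solubility), compound 1 gives only a limit, < 1000 nM, namely (the limit of < 1000 nM in this assay, at which 1 of the 3 values shown sits). Compound 2 `O=C(Nc1ccnnc1)c1cc(N2CCC(F)CC2)ccc1OCc1ccccc1` gives 20000 nM in this assay, and compound 3 `O=C(Nc1ccnnc1)c1cc(N2CCC(O)CC2)ccc1OCc1ccccc1` gives 28000 nM. Both replacements were large steps upward: an at least 20-fold higher number from compound 1 to compound 2 (1.30 log units; beyond the scatter) and an at least 28-fold higher number from compound 1 to compound 3 (1.44 log units; beyond the scatter), whereas a 1.4-fold higher number from compound 2 to compound 3 (0.15 log units; within the scatter) lies within the scatter. Compound 4 `O=C(Nc1ccnnc1)c1cc(N2CCC(CO)CC2)ccc1OCc1ccccc1` is not yet measured; it differs from compound 1 by 4-(hydroxymethyl)piperidin-1-yl in place of trifluoromethyl on an aromatic carbon. Given the two measured piperidinyl steps an at least 20-fold higher number from compound 1 to compound 2 (1.30 log units; beyond the scatter) and an at least 28-fold higher number from compound 1 to compound 3 (1.44 log units; beyond the scatter), a similarly large upward step is expected, an at least 28-fold higher number from compound 1 to compound 4 (1.44 log units; beyond the scatter). Compound 4 is accordingly estimated at 28000 nM in this assay, expected to fall between 12000 nM and 65000 nM.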

Compound 4, solubility: 323000 nM
Compound 4: the middle estimate sits 12-fold (1.06 log units) below what was measured; the whole stated range lies below it.
By their numbers in this assay, from the lowest: compounds 2 and 3 (each within the scatter of the next); then compound 4. At a limit, below all of these: compound 1.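

In this assay, the substituent on the piperidine now separates the compounds, although fluoro and hydroxy did not: hydroxymethyl in place of hydroxy gives a 12-fold higher number from compound 3 to compound 4 (1.06 log units; beyond the scatter), and hydroxymethyl in place of fluoro gives a 16-fold higher number from compound 2 to compound 4 (1.21 log units; beyond the scatter). The full replacement of trifluoromethyl gives an at least 320-fold higher number from compound 1 to compound 4 (2.50 log units; beyond the scatter). That step starts from a limit of the assay: the limit of < 1000 nM in this assay, at which 1 of the 4 values shown sits.

On these data alone, it remains open whether this jump depends on the free hydroxy or on the added carbon. A methoxymethyl group, a 2-hydroxyethyl chain or an aminomethyl group on the piperidine would help separate these.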